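This account rests on a few compounds, and the source may have more. Where it says the series, first, only, none or still open, it means among the compounds named here.

Measured so far:
Compound 1 `CCS(=O)(=O)Nc1cccc(-c2c[nH]cn2)c1` — in an assay on isolated protein (Cricetulus griseus) for binding affinity to Alpha-1B adrenergic receptor (Mesocricetus auratus), read by radioligand binding (on this read-out higher numbers stand for weaker inhibition and lower numbers for stronger inhibition), compound 1 gives < 10000 nM, which is a limit of the assay rather than a number.
Compound 2 `CCS(=O)(=O)Nc1cccc(Sc2c[nH]cn2)c1` — in this assay compound 2 gives < 10000 nM, again a limit of the assay.

Compound 2 thus stands only at a limit, and both values shown sit there (the limit of < 10000 nM in this assay, at which 2 of the 2 values shown sit). The step that the two limits leave unreadable from compound 1 to compound 2 accordingly has no readable size. Compound 3 `CCS(=O)(=O)Nc1cccc(C2CCNC2)c1` differs from compound 2 by pyrrolidin-3-yl in place of (1H-imidazol-4-yl)sulfanyl on an aromatic carbon. Among the compounds with values here, no measured step bears on this change, so no direction can be drawn from the numbers. The expected step is a step that the limit leaves unreadable from compound 2 to compound 3, a guess only. Compound 3 is therefore estimated at 3000 nM, with a range from 300 nM to 30000 nM.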

Compound 3, inhibition constant: < 10000 nM
Compound 3 was reported as a limit; the forecaster's own chance of this, stated with the estimate: 40%; the middle value lies beyond the limit too.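

No step from compound 1 or compound 2 to compound 3 can be read, since all three stand at a limit: the limit of < 10000 nM in this assay, at which 3 of the 3 values shown sit. The compounds shown leave open how these three rank in this assay.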